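Swapping 4-iodophenyl for thiophen-2-yl

A few compounds are considered here, and "the series" means these few. Any claim that something is new, unique, unknown or untested is made for them only; others in the source may bear on it.

Measured in an ADME assay on L929 cells (Mus musculus) for cytotoxicity, read by resazurin assay, with a stated time of 72 h; a lower number here means a stronger inhibitor, a higher number a weaker inhibitor:
compound 1 `Cc1cccc(C(=O)/C=C/c2ccc3c(c2)B(O)OC3)c1`: 8.56 ug/mL
compound 2 `O=C(/C=C/c1ccc2c(c1)B(O)OC2)c1ccc(I)cc1`: > 10 ug/mL

Compound 2 has no exact number, only a limit of the assay, > 10 ug/mL. Compound 3 `O=C(/C=C/c1ccc2c(c1)B(O)OC2)c1cccs1` keeps the shared core but carries thiophen-2-yl in place of 4-iodophenyl on a carbonyl carbon. Among the compounds with values here, only one measured step bears on this, since it also exchanges the group on a carbonyl carbon: an at least 1.1-fold higher number from compound 1 to compound 2 (0.06 log units; that floor lies within the scatter). That step gives a minimum and not a true size, and its minimum is too small to separate the two compounds. A step beyond the usual scatter in this assay is therefore not expected, and any direction is only tentative. The estimated step is an at least 1.2-fold lower number from compound 2 to compound 3 (0.09 log units; that floor lies within the scatter). Compound 3 is expected to give 8 ug/mL, with an estimated range from 3 ug/mL to 15 ug/mL.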

Compound 3, half-maximal inhibitory concentration: > 10 ug/mL
Compound 3 was reported as a limit; the forecaster's own chance of this, stated with the estimate: 40%; middle value at least 1.2-fold (0.09 log units) away from the limit.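

In this assay compound 3 gives > 10 ug/mL, which is a limit of the assay and not a number. Within the data shown here, measured against the only exact value, replacing 3-methylphenyl with thiophen-2-yl on the carbonyl carbon gives an at least 1.1-fold higher number from compound 1 to compound 3 (0.06 log units; that floor lies within the scatter), so this minimum cannot be told apart from scatter and the true size may be larger. Thiophen-2-yl is thus the second group at this position, after 4-iodophenyl, to end at the limit, and the step between compound 2 and compound 3 cannot be read for this reason: the limit of > 10 ug/mL in this assay, at which 2 of the 3 values shown sit.

Going by these compounds, it remains open how far beyond the limit compound 2 and compound 3 truly lie, and whether they differ at all. Also open, on these data alone, is whether a different kind of group on this carbonyl carbon, such as an amine or a carboxylic acid, would move the reading in this assay beyond the scatter.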